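Propyl in place of nitrophenyl: a step without precedent

This account rests on a few compounds, and the source may have more. Where it says the series, first, only, none or still open, it means among the compounds named here.

The measured compounds:
compound 1 `O=C(Nn1c(-c2cccc([N+](=O)[O-])c2)nc2c(-c3cccc(Cl)c3)n[nH]c2c1=O)c1ccccc1` — 89.8%
compound 2 `O=C(Nn1c(-c2cccc([N+](=O)[O-])c2)nc2c(-c3ccc(Cl)cc3)n[nH]c2c1=O)c1ccccc1` — 87.8%
compound 3 `O=C(Nn1c(-c2cccc([N+](=O)[O-])c2)nc2c(CCc3ccccc3)n[nH]c2c1=O)c1ccccc1` — 89.7%

In a functional assay on HT-29 cells (Homo sapiens) for cytotoxicity, read by sulforhodamine B assay, with a stated time of 2 days, tested at 100 uM (a lower number here means less inhibition, a higher number more inhibition at the concentration tested (going by the name of the read-out)), compound 1 gives 89.8%, compound 2 gives 87.8% and compound 3 gives 89.7%. Compound 2 has the lowest of the three numbers, yet the step of a number 2 percentage points lower from compound 1 to compound 2 (within the scatter) and the step of a number 1.9 percentage points higher from compound 2 to compound 3 (within the scatter) are both within the scatter, as is a number 0.1 percentage points lower from compound 1 to compound 3 (within the scatter); the three compounds are indistinguishable in this assay.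

Compound 4 `CCCc1nc2c(-c3ccc(Cl)cc3)n[nH]c2c(=O)n1NC(=O)c1ccccc1` is not yet measured. It differs from compound 2 as follows: propyl in place of 3-nitrophenyl on an aromatic carbon. Among the compounds with values here, no measured step touches this position: all three measured steps swap the group on the other aromatic carbon, and none of them moved this assay beyond the scatter. Within the data shown here, there is therefore no measured precedent for the step from compound 2 to compound 4, and the flat result of the three measured steps cannot be carried over to it.

Among the measured compounds shown here, with no step bearing on the change, the estimate for compound 4 can only lean on the narrow band of the measured values, with a wide margin: compound 4 is expected to give 78%, between 45% and 95%, which means an expected step of a number 9.8 percentage points lower from compound 2 to compound 4 (within the scatter).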

Compound 4, a percentage reported as inhibition, at one concentration (the size of the read-out at that concentration, not a potency): 91.1%
Beside the measured number, compound 4's estimate is 13.1 percentage points below it; measured number inside the range.
By their numbers in this assay, from the lowest: compounds 2, 3, 1 and 4 (each within the scatter of the next).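

Putting propyl in place of 3-nitrophenyl, on the aromatic carbon between two ring nitrogen atoms, gives a number 3.3 percentage points higher from compound 2 to compound 4 (within the scatter) in this assay. The earlier steps shown here showed a flat result only for the other aromatic carbon, whereas this one shows the same at a second position, even though the change removes a six-membered aromatic ring and both hydrogen-bond acceptors of the leaving group and takes the substituent from 9 heavy atoms to 3, so the 3-nitrophenyl group is not required for the inhibition read at this single concentration. Nothing in the data on hand accounts for this result.

On these data alone, since the read-out gives the size of the inhibition at one concentration and not a potency, it remains open whether compound 2 and compound 4 would separate at lower concentrations. Also open, as far as these compounds go, is whether the position stays as undemanding with a carboxylic acid, an amine or a chain longer than propyl on that aromatic carbon, or whether propyl behaves the same alongside the 3-chlorophenyl and phenethyl groups of the other position.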